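The source may hold more compounds than are shown below. What is called first, only, known or untested is meant among the compounds shown, and "the series" means these compounds.

- Compound 1 `CC(C)c1cc2c3c(c1OC(=O)c1ccccc1)OC(=O)[C@@]31CCCC(C)(C)[C@@H]1CC2`: 512000 nM
- Compound 2 `CC(C)c1cc2c3c(c1OC(=O)c1cccnc1)OC(=O)[C@@]31CCCC(C)(C)[C@@H]1CC2`: 296000 nM

Both compounds were measured in an ADME assay on MRC5 cells (Homo sapiens) for cytotoxicity, read by neutral red uptake, with a stated time of 24 h; a lower number here means a stronger inhibitor, a higher number a weaker inhibitor. For the measured compounds named here, their values cannot be told apart, so compound 2 stands level with its only neighbour: the single measured step is a 1.7-fold lower number from compound 1 to compound 2 (0.24 log units; within the scatter).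

Compound 3 `CC(C)c1cc2c3c(c1OC(=O)Cc1c[nH]c4ccccc14)OC(=O)[C@@]31CCCC(C)(C)[C@@H]1CC2` differs from compound 2 by one change: (1H-indol-3-yl)methyl in place of pyridin-3-yl on a carbonyl carbon. In words, (1H-indol-3-yl)methyl replaces pyridin-3-yl on a carbonyl carbon. Going by the values given here, the measured step bears on this change since it altered the group at the same place, but no measured compound carries the new group. Among the compounds with values here, with only that step as a guide, no step beyond the scatter is expected in this assay, and neither direction is favoured. The estimated change is a 1.0-fold higher number from compound 2 to compound 3 (0.01 log units; within the scatter). Compound 3 is expected at 300000 nM, with an estimated range of 110000 nM to 650000 nM.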

Compound 3, half-maximal inhibitory concentration: 109000 nM
Compound 3: middle estimate off by 2.8-fold (0.44 log units), on the high side; the measured number lies below the stated range.
By their numbers in this assay, from the lowest: compound 3; then compounds 2 and 1 (each within the scatter of the next).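

In this assay the group on this carbonyl carbon proves able to move the number beyond the scatter, which the swap between phenyl and pyridin-3-yl did not show: (1H-indol-3-yl)methyl gives a 2.7-fold lower number from compound 2 to compound 3 (0.43 log units; beyond the scatter) and a 4.7-fold lower number from compound 1 to compound 3 (0.67 log units; beyond the scatter) as modest steps. Both steps point the same way and start from two compounds that stand level with each other. No evidence at hand accounts for these steps.

The entering group brings a second aromatic ring, a hydrogen-bond donor and a methyl link at once, and the compounds shown do not separate these parts; a benzyl group or an indol-3-yl set directly on the carbonyl carbon would bear on that. On these data alone, how an amine, a carboxylic acid or a longer chain would read at this place also remains open.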